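This account rests on a few compounds, and the source may have more. Where it says the series, first, only, none or still open, it means among the compounds named here.

Of the compounds shown here, three built on one shared core have been tested in a functional assay on IGROV-1 cells (Homo sapiens) for inhibition, read by sulforhodamine B assay, with a stated time of 48 h; on this read-out higher numbers stand for weaker inhibition of growth and lower numbers for stronger inhibition of growth. Compound 1 `COc1cc(-c2nn(-c3cccc(NC(=O)c4cccc(C(F)(F)F)c4)c3)cc2-c2ccncc2)ccc1Cl` gives 1830 nM. Compound 2 `COc1cc(-c2nn(-c3cccc(NC(=O)Nc4ccc(Cl)c(Cl)c4)c3)cc2-c2ccncc2)ccc1Cl` gives 1180 nM. Compound 3 `COc1cc(-c2nn(-c3cccc(NC(=O)Nc4cccc(C(F)(F)F)c4)c3)cc2-c2ccncc2)ccc1Cl` gives 1060 nM. Compound 3 has the lowest number of the three, but the differences are small: the step of a 1.1-fold lower number from compound 2 to compound 3 (0.05 log units; within the scatter) and the step of a 1.7-fold lower number from compound 1 to compound 3 (0.24 log units; within the scatter) both stay within the usual scatter of repeated measurements, so no order among the three can be claimed.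

Compound 4 `COc1cc(-c2nn(-c3cccc(NC(=O)c4ccc(Cl)c(C(F)(F)F)c4)c3)cc2-c2ccncc2)ccc1Cl` has not yet been measured in this assay . Relative to compound 3 it carries the change (4-chloro-3-(trifluoromethyl)phenyl in place of (3-(trifluoromethyl)phenyl)amino on a carbonyl carbon). Two of the measured steps bear on this. The step of a 1.7-fold lower number from compound 1 to compound 3 (0.24 log units; within the scatter) shows that exchanging an amide-type linkage for a urea-type linkage at the carbonyl carbon made no difference beyond the scatter, and the step of a 1.6-fold lower number from compound 1 to compound 2 (0.19 log units; within the scatter) shows that exchanging a trifluoromethyl-bearing ring for a dichloro-bearing ring likewise stayed within the scatter. Within the data shown here, compound 4 combines the reverse of the first exchange with an extra chlorine on the outer ring, so no step beyond the scatter is expected in this assay . The expected step is a 1.4-fold higher number from compound 3 to compound 4 (0.15 log units; within the scatter). Compound 4 is therefore estimated to give about 1500 nM, with a likely range from 700 nM to 3500 nM.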

Compound 4, concentration for 50% growth inhibition: 2150 nM
Beside the measured number, compound 4's estimate is 1.4-fold (0.16 log units) below it; the measured number falls inside the stated range.
By their numbers in this assay, from the lowest: compounds 3, 2, 1 and 4 (each within the scatter of the next, the first and the last beyond it).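

In this assay, replacing (3-(trifluoromethyl)phenyl)amino on the carbonyl carbon with 4-chloro-3-(trifluoromethyl)phenyl gives a 2.0-fold higher number from compound 3 to compound 4 (0.31 log units; beyond the scatter) and so yields the first modest difference in this set that clears the scatter, which the three earlier compounds could not show. This result stands alone, since the matching exchange starting from the dichlorophenyl urea gives a 1.8-fold higher number from compound 2 to compound 4 (0.26 log units; within the scatter) and chloro in place of hydrogen on an aromatic carbon gives a 1.2-fold higher number from compound 1 to compound 4 (0.07 log units; within the scatter), both of which stay within the scatter, so neither the added chlorine nor the exchange at the carbonyl carbon has a firm effect across all the pairs. The group that leaves holds a hydrogen-bond donor and the group that enters holds none, but nothing available here connects that difference to the step.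

Still open, as far as these compounds go, is how a urea-type linkage carrying the 4-chloro-3-(trifluoromethyl)phenyl ring would compare, as such a compound would separate the added chlorine from the change of linkage. Also open, from the compounds shown here alone, is whether an amine or a carboxylic acid on the outer ring, or a longer chain between the carbonyl and that ring, would move the number further.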